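The compounds below may be only part of what the source reports. "The series", "measured", "known", "first", "only" and "open" are said of these compounds alone.

Compound 1 `CC(C)[C@H](NC(=O)COc1cccc2ccccc12)C(=O)N[C@@H](CC(=O)O)C(=O)COc1cccc2ccccc12`, compound 2 `CC(C)[C@H](NC(=O)COc1cccc2ccccc12)C(=O)N[C@@H](CC(=O)O)C(=O)COc1ccc(C(N)=O)cc1` and compound 3 `CC(C)[C@H](NC(=O)COc1cccc2ccccc12)C(=O)N[C@@H](CC(=O)O)C(=O)COc1cc(F)cc(F)c1` share one core and differ only in the aryl group sitting on an oxygen on a saturated carbon. In a functional assay on Jurkat cells (Homo sapiens) (on this read-out lower numbers stand for stronger inhibition and higher numbers for weaker inhibition), compound 1 gives only a limit, > 100000 nM. Compound 2 likewise reaches only a limit of > 100000 nM in this assay. Compound 3 also shows only a limit, > 100000 nM. Because of the limit of > 100000 nM in this assay, at which 3 of the 3 values shown sit, the steps a step that the two limits leave unreadable from compound 1 to compound 3 and a step that the two limits leave unreadable from compound 2 to compound 3 cannot be read in size. Compound 4 `CC(C)[C@H](NC(=O)COc1cccc2ccccc12)C(=O)N[C@@H](CC(=O)O)C(=O)COc1cccc(C(F)(F)F)c1F` carries 2-fluoro-3-(trifluoromethyl)phenyl in place of 3,5-difluorophenyl on an oxygen on a saturated carbon. Within the data shown here, no measured step shows a readable change for swapping this aryl group, so compound 4 is expected to stay near the limit, with an estimated step that the limit leaves unreadable from compound 3 to compound 4. The estimate for compound 4 is 150000 nM, between 50000 nM and 500000 nM.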

Compound 4, half-maximal inhibitory concentration: 50400 nM
Compound 4: middle estimate off by 3.0-fold (0.47 log units), on the high side; low and high end bracket the measured number.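

Among these compounds, compound 4 is the first compound here to give a real number rather than a limit in this assay, so the aryl group on this oxygen can change the read-out enough to be measured. Bringing in 2-fluoro-3-(trifluoromethyl)phenyl gives an at least 1.9-fold lower number from compound 3 to compound 4 (0.29 log units; that floor lies within the scatter), an at least 1.9-fold lower number from compound 2 to compound 4 (0.29 log units; that floor lies within the scatter) and an at least 1.9-fold lower number from compound 1 to compound 4 (0.29 log units; that floor lies within the scatter). These steps are only floors, because the other three compounds give no real number: the limit of > 100000 nM in this assay, at which 3 of the 4 values shown sit.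

On these data alone, it remains open whether the single fluorine, the trifluoromethyl or both together account for the readable value. As far as these compounds go, it is also open how a nitrile or an amine on this aryl ring would read.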